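Phenyl to 4-chlorophenyl: the next step in the series

The source may report more compounds than this note shows. Statements on the series, on what has been measured and on what is new or still open speak of the compounds shown alone.

In a functional assay on HeLa cells (Homo sapiens) for inhibition, read by MTT assay, with a stated time of 48 h (a lower number here means a stronger inhibitor, a higher number a weaker inhibitor), compound 1 `Cc1ccc(-c2nc3ccccn3c2Sc2ccccc2)cc1` gives 86700 nM, compound 2 `C(=C/c1nc2ccccn2c1Sc1ccccc1)\c1ccccc1` gives 35500 nM and compound 3 `c1ccc(Sc2c(-c3cccs3)nc3ccccn23)cc1` gives 19900 nM. Two steps are modest but beyond the scatter: a 2.4-fold lower number from compound 1 to compound 2 (0.39 log units; beyond the scatter) and a 4.4-fold lower number from compound 1 to compound 3 (0.64 log units; beyond the scatter). By contrast, a 1.8-fold lower number from compound 2 to compound 3 (0.25 log units; within the scatter) lies within it, so compound 3 shares the low end of this small range with compound 2.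

Compound 4 `Clc1ccc(Sc2c(-c3cccs3)nc3ccccn23)cc1` keeps the thiophen-2-yl group of compound 3 and adds one change: chloro in place of hydrogen on an aromatic carbon. Within the data shown here, no measured step touches the ring that takes the chloro. All three exchange the group at another place, so they bear on the new step only as a guide to size, the largest being a 4.4-fold lower number from compound 1 to compound 3 (0.64 log units; beyond the scatter). Direction cannot be read from them. A small move is expected in this assay, leaning lower and probably within the scatter: a 1.4-fold lower number from compound 3 to compound 4 (0.15 log units; within the scatter). For compound 4 the estimated value is 14000 nM, with an expected range of 6000 nM to 40000 nM.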

Compound 4, half-maximal inhibitory concentration: 74100 nM
Estimate against measurement, compound 4: 5.3-fold (0.72 log units) below; the whole stated range lies below it.
By their numbers in this assay, from the lowest: compounds 3 and 2 (each within the scatter of the next); then compounds 4 and 1 (each within the scatter of the next).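

In this assay, this is the first change shown on the phenyl ring that carries the new group, and it gives a 3.7-fold higher number from compound 3 to compound 4 (0.57 log units; beyond the scatter). This ring is therefore not a silent part of the series: a single chloro, on an aromatic carbon para to a large group, gives a modest step, as does a 4.4-fold lower number from compound 1 to compound 3 (0.64 log units; beyond the scatter), the group exchange at the other place, but toward weaker inhibition, so within this one pair the added chloro is unfavourable. Nothing available explains why this change raises the number.

Open, as far as these compounds go, is whether the step is specific to chloro or would also follow from fluoro, methoxy or an amine at the same place. Also open, from the compounds shown here alone, is whether chloro has the same effect when 4-methylphenyl or 2-phenylethenyl replaces thiophen-2-yl.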